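This account rests on a few compounds, and the source may have more. Where it says the series, first, only, none or still open, it means among the compounds named here.

The measured compounds in a functional assay on the whole organism (strain Wistar) for inhibition, with Rattus norvegicus as the target, read by paw edema, with stated times of 30 min and 3 h, at a dose of 100 mg/kg by the oral route (on this read-out higher numbers stand for more inhibition at the one dose given (going by the name of the read-out) and lower numbers for less inhibition), are:

compound 1, `COc1cc(C(=O)N(C)C)nn1-c1ccccc1`: 47.5%
compound 2, `CC(C)Oc1cc(C(=O)N(C)C)nn1-c1ccccc1`: 43.9%
compound 3, `CCCCOc1cc(C(=O)N(CC)CC)nn1-c1ccccc1`: 44.1%

Compound 2 has the lowest number of the three, but every gap is within the scatter: compound 3 is nearest, compound 1 furthest, and neither can be called different from compound 2 in this assay. Compound 4, `CC(C)CCOc1cc(C(=O)N(C)C)nn1-c1ccccc1`, is not yet measured. It differs from compound 2 by isopentyl in place of isopropyl on an oxygen on an aromatic ring.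

Going by the values given here, only one measured step bears on this change, the lengthening of the same chain on the same oxygen: a number 3.6 percentage points lower from compound 1 to compound 2 (within the scatter), a step within the scatter. Compound 3 carries a longer chain on that oxygen as well, but it also differs at the amide, so its value is read alongside the others only as a number in the same range. Among the compounds with values here, with the one relevant step flat, the further growth of the chain in compound 4 is expected to give no step beyond the scatter in this assay, in either direction, so that a number 0.1 percentage points higher from compound 2 to compound 4 (within the scatter) is estimated to be small. Compound 4 is therefore expected to show about 44%, with a range from 34% to 54%.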

Compound 4, a percentage reported as inhibition, in the whole organism at one dose (the size of the read-out at that dose, not a potency): 25.3%
Compound 4: middle estimate off by 18.7 percentage points, on the high side; measured number outside the range, below it.
By their numbers in this assay, from the lowest: compound 4; then compounds 2, 3 and 1 (each within the scatter of the next).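

In this assay, going by these compounds alone, the isopentyl group gives the first step at this oxygen that lies beyond the scatter, with a number 18.6 percentage points lower from compound 2 to compound 4 (beyond the scatter) for isopentyl in place of isopropyl. Measured from the methyl ether, the same chain gives a number 22.2 percentage points lower from compound 1 to compound 4 (beyond the scatter) as well, whereas isopropyl in place of methyl gave only a number 3.6 percentage points lower from compound 1 to compound 2 (within the scatter) and so showed no effect of that change at this position. Nothing available explains why the number falls with the isopentyl group.

From the compounds shown here alone, whether an unbranched pentyl chain on this oxygen, with the same amide, would give a number like that of compound 4 stays open. So does whether a hydroxyl group or an amine at the end of the chain would bring the number back up.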